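Acetylating the Remaining Hydroxyl: From Compound 2 to Compound 3

This account rests on a few compounds, and the source may have more. Where it says the series, first, only, none or still open, it means among the compounds named here.

Measured compounds:
compound 1, `C=C1CC[C@@H]2[C@](C)(CO[Si](C)(C)C(C)(C)C)[C@H](O)CC[C@@]2(C)[C@@H]1C/C=C1/C(=O)OC[C@H]1OC(C)=O`: 10.7 uM
compound 2, `C=C1CC[C@@H]2[C@](C)(COC(C)=O)[C@H](O)CC[C@@]2(C)[C@@H]1C/C=C1/C(=O)OC[C@H]1O`: 15.3 uM

Both were tested in a functional assay on KB cells (Homo sapiens) for cytotoxicity, read by sulforhodamine B assay; a higher number here means that more compound is needed for the effect, a lower number that less compound is needed. Compound 2 holds the higher of the two numbers, yet compound 1 lies within the scatter of it, so the two cannot be ranked. Compound 3, `C=C1CC[C@@H]2[C@](C)(COC(C)=O)[C@H](O)CC[C@@]2(C)[C@@H]1C/C=C1/C(=O)OC[C@H]1OC(C)=O`, is not yet measured; it differs from compound 2 by acetyl in place of hydrogen on an oxygen on a saturated carbon. Within the data shown here, no measured step covers this change, so only a small shift is expected, in either direction but not beyond the scatter. The expected step is a 1.4-fold lower number from compound 2 to compound 3 (0.14 log units; within the scatter). Compound 3 is estimated at 11 uM, with a range from 4 uM to 30 uM.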

Compound 3, concentration for half-maximal effect: 26.4 uM
Estimate against measurement, compound 3: 2.4-fold (0.38 log units) below; low and high end bracket the measured number.
By their numbers in this assay, from the lowest: compounds 1, 2 and 3 (each within the scatter of the next, the first and the last beyond it).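

In this assay, replacing hydroxy with acetoxy gives a 1.7-fold higher number from compound 2 to compound 3 (0.24 log units; within the scatter), so this change cannot be told apart from repeat scatter. Among these compounds, putting a group of 3 heavy atoms in place of a group of 7 heavy atoms, on an oxygen on a saturated carbon, gives a 2.5-fold higher number from compound 1 to compound 3 (0.39 log units; beyond the scatter), the first step in this set beyond the scatter, though a modest one. Nothing measured here accounts for that step. From the compounds shown here alone, whether an amine or a longer chain on either oxygen would shift the number remains open.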